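Removing the methyl from a weak MNK1 inhibitor

This account rests on a few compounds, and the source may have more. Where it says the series, first, only, none or still open, it means among the compounds named here.

Measured compounds:
- compound 1 `Cc1cc(-c2cccnc2)ccc1C(N)=O`: 22000 nM
- compound 2 `CC(C)Oc1cc(-c2cncc(-c3cnn(C)c3)c2)ccc1C(N)=O`: 400 nM

Both compounds were tested in an assay on cells for inhibition of MAP kinase-interacting serine/threonine-protein kinase 1 (Homo sapiens), read by mobility shift assay, with stated times of 10 min and 60 min, in the presence of a further agent that is not named here; on this read-out higher numbers stand for weaker inhibition and lower numbers for stronger inhibition. Compound 1 gives the higher of the two numbers, so it stands as the weaker of the pair; compound 2 sits far below it, a gap beyond the usual scatter. Compound 2 carries several changes at once relative to compound 1, so no single one of them can be credited with that gap.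

The unmeasured compound 3 `NC(=O)c1ccc(-c2cccnc2)cc1` differs from compound 1 in one place only: hydrogen in place of methyl on an aromatic carbon. Going by the values given here, no measured pair in this set isolates that change, so the direction of its effect is unknown. In the absence of guidance, the step of a 1.1-fold higher number from compound 1 to compound 3 (0.06 log units; within the scatter) is expected to be small, likely within the scatter. On that basis compound 3 is estimated at 25000 nM, with a plausible range from 8000 nM to 80000 nM, and its value in this assay awaits measurement.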

Compound 3, half-maximal inhibitory concentration: 8800 nM
Estimate against measurement, compound 3: 2.8-fold (0.45 log units) above; low and high end bracket the measured number.
By their numbers in this assay, from the lowest: compound 2; then compound 3; then compound 1.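

In this assay, the methyl on this aromatic carbon, ortho to a carbamoyl group, proves unnecessary for inhibition: replacing it with hydrogen gives a 2.5-fold lower number from compound 1 to compound 3 (0.40 log units; beyond the scatter) and so moves the result toward stronger inhibition, though only modestly. Going by these compounds alone, this is the first comparison in the set that changes a single place, and it shows that this position responds to what sits on it, with hydrogen doing better here than methyl. No measurement shown here bears on why the number moves.

Going by these compounds, whether a fluorine, a methoxy group or an amine on this carbon would lower the number further or raise it remains open. One pair also cannot show whether the same change would act the same way on a different core.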